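Methyl placement on the pyridine of a diketopiperazine series

The source may report more compounds than this note shows. Statements on the series, on what has been measured and on what is new or still open speak of the compounds shown alone.

Measured compounds:
- compound 1 `CC[C@H](C)[C@@H]1C(=O)N[C@H](C2Cc3ccccc3C2)C(=O)N1[C@@H](C(=O)N(C)C)c1ccc(C)nc1C`: 0.0794 nM
- compound 2 `CC[C@H](C)[C@@H]1C(=O)N[C@H](C2Cc3ccccc3C2)C(=O)N1[C@@H](C(=O)NC)c1cnc(C)cc1C`: 0.0631 nM

In an assay on isolated protein for displacement of a labelled ligand from Oxytocin receptor (Homo sapiens) (on this read-out higher numbers stand for weaker inhibition and lower numbers for stronger inhibition), compound 1 gives 0.0794 nM and compound 2 gives 0.0631 nM; the two numbers fall within the usual scatter of each other, so no order between them is claimed. Compound 3 `CC[C@H](C)[C@@H]1C(=O)N[C@H](C2Cc3ccccc3C2)C(=O)N1[C@@H](C(=O)N(C)C)c1cc(C)cnc1C` is not yet measured. It differs from compound 1 by 2,5-dimethylpyridin-3-yl in place of 2,6-dimethylpyridin-3-yl on a saturated chain carbon bound to an amide-type nitrogen in a ring and a carbonyl carbon. Going by the values given here, no measured pair isolates this change, so only a small step is expected, possibly none beyond the scatter, as a 1.3-fold higher number from compound 1 to compound 3 (0.10 log units; within the scatter). On that basis compound 3 is estimated at 0.1 nM in this assay, with a likely range from 0.03 nM to 0.4 nM.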

Compound 3, inhibition constant: 0.794 nM
Compound 3: middle estimate off by 7.9-fold (0.90 log units), on the low side; the whole stated range lies below it.
By their numbers in this assay, from the lowest: compounds 2 and 1 (each within the scatter of the next); then compound 3.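

Moving one methyl on the pyridine is not a silent change at this position: in this assay, 2,5-dimethylpyridin-3-yl in place of 2,6-dimethylpyridin-3-yl gives a 10-fold higher number from compound 1 to compound 3 (1.00 log units; beyond the scatter). The two compounds have the same atoms joined differently, so the arrangement on this ring alone separates them, which compound 1 and compound 2 could not show as they differ in more than one place. Nothing available accounts for the step.

As far as these compounds go, it remains open whether the same change costs as much with the methyl amide of compound 2. Also open, from the compounds shown here alone, is how an ethyl or methoxy group in place of the moved methyl would read.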